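Methyl Added Beside the Indazole Nitrogen of Compound 1

This account rests on a few compounds, and the source may have more. Where it says the series, first, only, none or still open, it means among the compounds named here.

Compound 1 `FC(F)(F)c1ccccc1-c1ccc2[nH]ncc2c1`: in an assay on CHO-TREX cells for antagonist activity at transient receptor potential cation channel subfamily A member 1 (Homo sapiens), read by FLIPR and calcium flux, with a stated time of 10 min (on this read-out higher numbers stand for weaker inhibition and lower numbers for stronger inhibition), compound 1 gives 164 nM
Compound 2 `Fc1ccc(C(F)(F)F)c(-c2ccc3[nH]ncc3c2)c1`: in this assay compound 2 gives 306 nM

Compound 1 stands lowest of the two numbers, and its nearest neighbour is compound 2, reached by a 1.9-fold higher number from compound 1 to compound 2 (0.27 log units; within the scatter), a change that stays within the scatter. Compound 3 `Cc1cc(-c2ccccc2C(F)(F)F)cc2cn[nH]c12` differs from compound 1 by methyl in place of hydrogen on an aromatic carbon. Among the compounds with values here, no measured step touches this part of the shared core; the only step on record, from compound 1 to compound 2, sits on the other ring and was within the scatter. Compound 3 is therefore expected to show a 1.2-fold higher number from compound 1 to compound 3 (0.09 log units; within the scatter), nothing beyond the scatter. The estimate for compound 3 is 200 nM, in the range 70 nM to 600 nM.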

Compound 3, half-maximal inhibitory concentration: 6720 nM
Estimate against measurement, compound 3: 34-fold (1.53 log units) below, outside the stated range (above it).
By their numbers in this assay, from the lowest: compounds 1 and 2 (each within the scatter of the next); then compound 3.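

In this assay, within the data shown here, methyl in place of hydrogen on an aromatic carbon, ortho to a fused ring, gives a 41-fold higher number from compound 1 to compound 3 (1.61 log units; beyond the scatter) as a large step, whereas the only earlier step, a 1.9-fold higher number from compound 1 to compound 2 (0.27 log units; within the scatter) on a different carbon, stayed within the scatter. This shows that inhibition can depend strongly on a single added carbon at this place on the shared core. Nothing measured here accounts for the loss. From the compounds shown here alone, it remains open whether fluoro, chloro or methoxy at this same carbon would raise the number as far, or whether an ethyl group would raise it further.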